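This account rests on a few compounds, and the source may have more. Where it says the series, first, only, none or still open, it means among the compounds named here.

Measured compounds in a functional assay on HT-29 cells (Homo sapiens) for inhibition, read by MTT assay, with a stated time of 72 h; on this read-out lower numbers stand for stronger inhibition of growth and higher numbers for weaker inhibition of growth:
compound 1 `O=S(=O)(NCCNCc1cccc2ccccc12)c1cc(C(F)(F)F)cc(C(F)(F)F)c1` gives 16000 nM
compound 2 `COc1ccc(CNCCCNS(=O)(=O)c2cc(C(F)(F)F)cc(C(F)(F)F)c2)cc1OC` gives 2700 nM
compound 3 `CC(C)(C)c1ccc(CNCCNS(=O)(=O)c2cc(C(F)(F)F)cc(C(F)(F)F)c2)cc1` gives 14000 nM

Compound 2 holds the lowest number of the three in this assay; compound 3 and compound 1 lie beyond the scatter from it. Compound 1 and compound 3 differ from compound 2 in more than one place, so their gap to compound 2 cannot be assigned to any single change.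

Compound 4 `O=S(=O)(NCCCNCc1cccc(Cl)c1)c1cc(C(F)(F)F)cc(C(F)(F)F)c1` is not yet measured. It keeps the rest of compound 2 and differs only at the aryl group: 3-chlorophenyl in place of 3,4-dimethoxyphenyl on a saturated chain carbon bound to an amine nitrogen

Among the measured compounds shown here, only one measured step touches the same place: a 1.1-fold lower number from compound 1 to compound 3 (0.06 log units; within the scatter). There the aryl group changed and the number did not move beyond the scatter. For the measured compounds named here, that is the only guide; no measured pair shows a 3,4-dimethoxyphenyl turned into a 3-chlorophenyl. Because a 1.1-fold lower number from compound 1 to compound 3 (0.06 log units; within the scatter) was flat, a step of modest size is expected for compound 4, more likely towards a higher number than a lower one, since compound 2 already holds the lowest number seen.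

For compound 4 the expected step is a 1.9-fold higher number from compound 2 to compound 4 (0.27 log units; within the scatter). Compound 4 is estimated at 5000 nM in this assay, with a range from 1500 nM to 17000 nM.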

Compound 4, concentration for 50% growth inhibition: 14000 nM
Beside the measured number, compound 4's estimate is 2.8-fold (0.45 log units) below it, and the stated range covers the measured number.
By their numbers in this assay, from the lowest: compound 2; then compounds 3, 4 and 1 (each within the scatter of the next).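

In this assay, among the compounds shown here, the aryl group on a saturated chain carbon bound to an amine nitrogen proves able to move the number: putting 3-chlorophenyl in place of 3,4-dimethoxyphenyl gives a 5.2-fold higher number from compound 2 to compound 4 (0.71 log units; beyond the scatter) whereas the only earlier step at this place (a 1.1-fold lower number from compound 1 to compound 3 (0.06 log units; within the scatter)) stayed flat. The place is therefore not indifferent to the aryl group, and within this pair the lower number goes with 3,4-dimethoxyphenyl; the flat step and the new one also stand on different chains, so neither can be carried over to the other. Nothing at hand accounts for the new step.

Compound 4 differs from compound 2 both in the loss of the two methoxy groups and in the arrival of the chlorine, so the compounds shown do not tell which of these carries the step. From the compounds shown here alone, a 3-methoxyphenyl, a 4-methoxyphenyl or a 3,4-dichlorophenyl group at this place would separate those parts, and whether 3,4-dimethoxyphenyl keeps its lower number on the chain of compound 1 also stays open.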